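This account rests on a few compounds, and the source may have more. Where it says the series, first, only, none or still open, it means among the compounds named here.

Measured in an ADME assay on S9 fraction from liver (Rattus norvegicus) for metabolic stability, with a stated time of 1 h; on this read-out higher numbers stand for a more stable compound and lower numbers for a less stable compound:
- compound 1 `N#Cc1cnc(NCc2cnccc2C(F)(F)F)cc1NC[C@H]1CC[C@H](O)CC1`: 6%
- compound 2 `N#Cc1cnc(NCc2cnccc2C(F)(F)F)cc1NCCC1CCOCC1`: 0%
- compound 3 `N#Cc1cnc(NCc2cnccc2C(F)(F)F)cc1N[C@H]1CC[C@@H](C(N)=O)CC1`: 30%

Of these three, compound 3 stands highest in this assay. The two steps that reach it are a number 24 percentage points higher from compound 1 to compound 3 (beyond the scatter) and a number 30 percentage points higher from compound 2 to compound 3 (beyond the scatter). The remaining step, a number 6 percentage points lower from compound 1 to compound 2 (within the scatter), shows no separation.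

Compound 4 `N#Cc1cnc(NCc2cnccc2C(F)(F)F)cc1N[C@H]1CC[C@@H](c2nc[nH]n2)CC1` keeps the shared core and differs at one place: 1H-1,2,4-triazol-3-yl in place of carbamoyl on a saturated ring carbon. A 1H-1,2,4-triazol-3-yl stands in place of carbamoyl on a saturated ring carbon.

Going by the values given here, no measured step exchanges the carbamoyl alone. Among the compounds with values here, the two steps reaching compound 3 replace the whole group on the nitrogen, so they show only that a change in this region can be modest in size, and they give no direction for this exchange. A step within the scatter is therefore expected, leaning slightly downward, though a modest move remains possible. The expected step is a number 5 percentage points lower from compound 3 to compound 4 (within the scatter). For compound 4 the estimated value is 25%, with an expected range from 8% to 48%.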

Compound 4, percent of the compound remaining: 29%
Estimate against measurement, compound 4: 4 percentage points below; the measured number falls inside the stated range.
By their numbers in this assay, from the lowest: compounds 2 and 1 (each within the scatter of the next); then compounds 4 and 3 (each within the scatter of the next).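

In this assay, 1H-1,2,4-triazol-3-yl in place of carbamoyl on the saturated ring carbon gives a number 1 percentage points lower from compound 3 to compound 4 (within the scatter), the first step shown that exchanges this group alone. At this place, then, a five-membered aromatic ring with 5 heavy atoms can stand in place of the 3 heavy atoms of carbamoyl without separating the two compounds, so the carbamoyl itself is not needed to keep the number seen for compound 3. Nothing available explains this outcome, and no cause can be assigned to it.

Still open, as far as these compounds go, is how a carboxylic acid, a primary amine or a tetrazole would read at this ring carbon. A single exchange also leaves open whether other five-membered aromatic rings, such as an oxadiazole or an imidazole, would behave like the 1H-1,2,4-triazol-3-yl.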